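Compound 3: 1H-tetrazol-5-yl for (methylsulfonyl)carbamoyl

The source may hold more compounds than are shown below. What is called first, only, known or untested is meant among the compounds shown, and "the series" means these compounds.

In a physicochemical assay for solubility, in phosphate buffer, measured as thermodynamic solubility, at pH 7.4 (on this read-out lower numbers stand for lower solubility and higher numbers for higher solubility), compound 1 `CS(=O)(=O)NC(=O)CCc1cn(-c2ccc(Br)cc2)nc1-c1ccc(Cl)cc1` gives 170000 nM and compound 2 `CS(=O)(=O)NC(=O)CCc1cn(-c2ccc(Br)cc2)nc1Cc1ccccc1` gives 200000 nM so the two numbers lie within the scatter of each other. For the measured compounds named here, the only measured step (a 1.2-fold higher number from compound 1 to compound 2 (0.07 log units; within the scatter)) is benzyl in place of 4-chlorophenyl on an aromatic carbon. It lies within the scatter, but it sits at a different place from the change considered here and bears on it only indirectly. Compound 3 `Clc1ccc(-c2nn(-c3ccc(Br)cc3)cc2CCc2nnn[nH]2)cc1` keeps the core of compound 1 and carries 1H-tetrazol-5-yl in place of (methylsulfonyl)carbamoyl on a saturated chain carbon, two bonds along the chain from an aromatic carbon. Going by the values given here, no measured step covers this exchange, so the range stays wide. The expected step (a 1.1-fold lower number from compound 1 to compound 3 (0.05 log units; within the scatter)) stays within the scatter, with no direction favoured. Compound 3 is estimated at 150000 nM in this assay (expected range 50000 nM to 300000 nM).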

Compound 3, solubility: 150000 nM
Estimate against measurement, compound 3: no gap at the digits printed; measured number inside the range.
By their numbers in this assay, from the lowest: compounds 3, 1 and 2 (each within the scatter of the next).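

In this assay, for the compounds shown here, this is the first measured exchange at this place: 1H-tetrazol-5-yl in place of (methylsulfonyl)carbamoyl on a saturated chain carbon gives a 1.1-fold lower number from compound 1 to compound 3 (0.05 log units; within the scatter) and so stays within the scatter. The earlier step concerned a different place, so the series now shows that this position also takes a change of group, from an open chain to a five-membered aromatic ring, with no read-out shift beyond the scatter. No measured evidence on the compounds bears on why the number holds.

On these data alone, whether the same exchange behaves alike on the benzyl compound 2 remains open. Also open, as far as these compounds go, is how a carboxylic acid, an amine or a longer chain would read at this place.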